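Vinyl in Place of Ethynyl: an Expected Toxicity Step

The source may hold more compounds than are shown below. What is called first, only, known or untested is meant among the compounds shown, and "the series" means these compounds.

Measured so far:
compound 1, `C=CCNC(=O)/C(C)=C(/C)c1ccc(Br)cc1`, gives 400 mg/kg in a toxicity assay on the whole organism (strain Icem-CET (SPF Caw)) for cytotoxicity, with Mus musculus as the target; on this read-out higher numbers stand for an effect only at larger amounts of compound and lower numbers for an effect already at smaller amounts
compound 2, `C#CCNC(=O)/C(C)=C(\C)c1ccc(Br)cc1`, gives 180 mg/kg in this assay

Compound 2 stands at the lowest of the two numbers; compound 1 lies above it, beyond the usual scatter. Compound 3, `C=CCNC(=O)/C(C)=C(\C)c1ccc(Br)cc1`, is not yet measured. It differs from compound 2 by vinyl in place of ethynyl on a saturated chain carbon bound to an amide-type nitrogen, propargyl becoming allyl. For the measured compounds named here, no measured pair shows exactly this step, but compound 1 also carries the allyl group and gives 400 mg/kg. For compound 3 the expected step is a 1.7-fold higher number from compound 2 to compound 3 (0.22 log units; within the scatter), a moderate rise near the edge of the scatter. Compound 3 is estimated at 300 mg/kg, within a range from 150 mg/kg to 600 mg/kg.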

Compound 3, dose for half-maximal effect: 120 mg/kg
Beside the measured number, compound 3's estimate is 2.5-fold (0.40 log units) above it; the measured number lies below the stated range.
By their numbers in this assay, from the lowest: compounds 3 and 2 (each within the scatter of the next); then compound 1.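

In this assay, propargyl becoming allyl on a saturated chain carbon bound to an amide-type nitrogen gives a 1.5-fold lower number from compound 2 to compound 3 (0.18 log units; within the scatter), so with the E double bond this change is not resolved. The allyl group alone therefore does not set the number of compound 1, since the step of a 3.3-fold lower number from compound 1 to compound 3 (0.52 log units; beyond the scatter) carries the same group at both ends. The double bond drawn Z in compound 1 and E in compound 3 is what separates this pair: the fact that compounds 1 and 3 differ only in the configuration as drawn.

On these data alone, whether the propargyl group tracks the same configuration gap stays open. As far as these compounds go, how a longer chain or an amine at this position would read also stays open.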